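Swapping (2-methoxyphenyl)amino for dipropylamino on a shared core

This account rests on a few compounds, and the source may have more. Where it says the series, first, only, none or still open, it means among the compounds named here.

In a functional assay on ECa-109 cells for inhibition, with ECa-109 cell line (Homo sapiens) as the target, read by sulforhodamine B assay (a higher number here means a weaker inhibitor, a lower number a stronger inhibitor), compound 1 `O=C1C=C(Nc2ccccc2F)C(=O)c2c1nc1n2[C@H]2OC[C@@H](O)[C@H]2OC1` gives 2760 nM. Compound 2 `COc1ccccc1NC1=CC(=O)c2nc3n(c2C1=O)[C@H]1OC[C@@H](O)[C@H]1OC3` gives > 4000 nM, which is a limit and not a number. Compound 3 `CCCN(CCC)C1=CC(=O)c2nc3n(c2C1=O)[C@H]1OC[C@@H](O)[C@H]1OC3` differs from it by dipropylamino in place of (2-methoxyphenyl)amino on a double-bonded ring carbon. Among the measured compounds shown here, the one measured step, an at least 1.4-fold higher number from compound 1 to compound 2 (0.16 log units; that floor lies within the scatter), is methoxy in place of fluoro on an aromatic carbon. It alters only the aromatic ring that now leaves, so it bears weakly here. The expected change is an at least 1.1-fold lower number from compound 2 to compound 3 (0.05 log units; that floor lies within the scatter), with no shift beyond the scatter anticipated in either direction. The estimate for compound 3 is 3500 nM, ranging from 1200 nM to 10000 nM.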

Compound 3, half-maximal inhibitory concentration: > 16000 nM
Compound 3: no number, only a limit (the forecaster's own chance of this, stated with the estimate: 40%); at least 4.5-fold (0.66 log units) between middle value and limit.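

Compound 3 gives no number, only a limit: the limit of > 16000 nM in this assay, at which 1 of the 3 values shown sits.

Dipropylamino in place of (2-fluorophenyl)amino at this double-bonded ring carbon gives an at least 5.7-fold higher number from compound 1 to compound 3 (0.76 log units; beyond the scatter), so this change weakens inhibition by more than the usual scatter. Compound 2 and compound 3 both carry limits, so the step between them cannot be read.

From the compounds shown here alone, it stays open whether the loss follows the aromatic ring or the hydrogen-bond donor that leave together. A methyl(phenyl)amino group, which keeps the ring without the donor, or a propylamino group, which keeps the donor without the ring, would separate the two.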